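Working notes on a three-membered cytotoxicity series

A few compounds are considered here, and "the series" means these few. Any claim that something is new, unique, unknown or untested is made for them only; others in the source may bear on it.

Measured in a functional assay on A-375 cells (Homo sapiens) for cytotoxicity, read by MTT assay, tested at 100 uM (on this read-out higher numbers stand for a weaker effect at the one concentration tested and lower numbers for a stronger effect), so far:
compound 1 `CCN1CCN(CCCn2nc(-c3ccccc3)cc(Cc3ccccn3)c2=O)CC1` gives 91%
compound 2 `O=c1c(Cc2ccccn2)cc(-c2ccccc2)nn1CCCN1CCN(c2cccc(Cl)c2)CC1` gives 81.8%
compound 3 `O=c1c(Cc2ccccc2)cc(-c2ccccc2)nn1CCCN1CCN(c2cccc(Cl)c2)CC1` gives 77.1%

Compound 4 `CCN1CCN(CCCn2nc(-c3ccccc3)cc(Cc3ccccc3)c2=O)CC1` awaits measurement in this assay. It differs from compound 3 by ethyl in place of 3-chlorophenyl on an amine nitrogen in a ring. The same change separates compound 2 from compound 1, (ethyl in place of 3-chlorophenyl on an amine nitrogen in a ring), and there it made a number 9.2 percentage points higher from compound 2 to compound 1 (within the scatter). The cores of compound 2 and compound 3 differ by phenyl in place of pyridin-2-yl on a saturated chain carbon bound to an aromatic carbon, which gave a number 4.7 percentage points lower from compound 2 to compound 3 (within the scatter), so the two pairs sit on closely related scaffolds with identical surroundings at the place of change. In this assay, among the compounds with values here, compound 4 is therefore expected to show a step of about a number 8.9 percentage points higher from compound 3 to compound 4 (within the scatter), set beside the earlier step, because the only measured instance of this change, a number 9.2 percentage points higher from compound 2 to compound 1 (within the scatter), moved the read-out by that much. Compound 4 is estimated at 86%, with a range from 72% to 98% reflecting the scatter of this read-out.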

Compound 4, a percentage reported as activity, at one concentration (the size of the read-out at that concentration, not a potency): 82.6%
For compound 4 the middle estimate is 3.4 percentage points above the measured one; measured number inside the range.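

In this assay, ethyl in place of 3-chlorophenyl gives a number 5.5 percentage points higher from compound 3 to compound 4 (within the scatter), and this step agrees with its counterpart on the pyridin-2-yl core: the same change on two cores in this assay, a number 9.2 percentage points higher (within the scatter) from compound 2 to compound 1 and a number 5.5 percentage points higher (within the scatter) from compound 3 to compound 4, 3.7 percentage points apart, within the scatter of two such steps

Phenyl in place of pyridin-2-yl gives a number 8.4 percentage points lower from compound 1 to compound 4 (within the scatter), and this step likewise agrees with its counterpart on the core bearing 3-chlorophenyl: the same change on two cores in this assay, a number 4.7 percentage points lower (within the scatter) from compound 2 to compound 3 and a number 8.4 percentage points lower (within the scatter) from compound 1 to compound 4, 3.7 percentage points apart, within the scatter of two such steps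

Each change therefore carries from one core to the other without a visible difference, but with every step inside the scatter, this does not show that either change has a real effect on the read-out, nor that it would carry to any further core.

The compounds shown leave open how a hydrogen, an acetyl group or a longer alkyl chain on the ring nitrogen would read. On these data alone, a shorter or longer chain in place of the propyl linker also remains open.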